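Swapping the aryl ether: chlorophenyl to fluorophenyl

The source may report more compounds than this note shows. Statements on the series, on what has been measured and on what is new or still open speak of the compounds shown alone.

Measured compounds:
compound 1 `Cc1cc(COc2ccccc2Cl)nc(-c2ccccn2)n1` — 3.4
compound 2 `COc1ccccc1OCc1cc(C)nc(-c2ccccn2)n1` — 2.5
compound 3 `Cc1cc(COc2cccc(C#N)c2)nc(-c2ccccn2)n1` — 2.7

In a physicochemical assay for lipophilicity, at pH 7.4 (a higher number here means a more lipophilic compound, a lower number a more polar compound), compound 1 gives 3.4, the highest of the three numbers; compound 3 comes nearest with 2.7, and compound 2 is furthest with 2.5. Going by the values given here, the only step between measured compounds that differs in one place is the one to compound 2, where methoxy stands in place of chloro on an aromatic carbon: a number 0.90 log units lower from compound 1 to compound 2 (beyond the scatter).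

Compound 4 `Cc1cc(COc2ccc(F)cc2)nc(-c2ccccn2)n1` has not yet been measured in this assay. Compared with compound 1 it differs as follows: 4-fluorophenyl in place of 2-chlorophenyl on an oxygen on a saturated carbon. Among the compounds with values here, no measured step covers this exchange directly; the nearest guide is that every change away from the 2-chlorophenyl of compound 1 has so far given a lower number, and the step to compound 2 was modest but beyond the scatter. Compound 4 is therefore expected to sit below compound 1 by a modest step, a number 0.50 log units lower from compound 1 to compound 4 (beyond the scatter), estimated at 2.9 with a range from 2.5 to 3.3.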

Compound 4, distribution coefficient: 3
Beside the measured number, compound 4's estimate is 0.10 log units below it, within the range that was stated.
By their numbers in this assay, from the lowest: compounds 2, 3 and 4 (each within the scatter of the next, the first and the last beyond it); then compound 1.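

In this assay, 4-fluorophenyl in place of 2-chlorophenyl on the oxygen lowers the number (a number 0.40 log units lower from compound 1 to compound 4 (beyond the scatter)), showing that this position responds to an exchange of one halogen-bearing phenyl for another, with the heavy-atom count unchanged and no hydrogen-bond donor or acceptor gained or lost. With this step, compound 1 stays the highest of the four compounds, and no exchange at this position shown so far goes against that. Nothing measured here explains the size or direction of the step.

This step alters both the halogen and its place on the phenyl, so 4-chlorophenyl or 2-fluorophenyl on the same oxygen would be needed to separate the two changes. As far as these compounds go, how an aminophenyl or a carboxyphenyl would read at this position also remains open.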